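This account rests on a few compounds, and the source may have more. Where it says the series, first, only, none or still open, it means among the compounds named here.

Measured so far in a functional assay on K562 cells (Homo sapiens) for cytotoxicity, read by thymidine incorporation, with a stated time of 48 h; a higher number here means a weaker inhibitor, a lower number a stronger inhibitor:
compound 1 `O=c1nc2c(cn1Cc1ccccc1)ncn2Cc1ccccc1` gives > 10 ug/mL, a limit of the assay.
compound 2 `O=c1nc2c(ncn2Cc2ccccc2)c(C#Cc2ccccc2)n1Cc1ccccc1` gives 0.7 ug/mL.

Compound 1 sits at a limit of the assay (the limit of > 10 ug/mL in this assay, at which 1 of the 2 values shown sits). Within the data shown here, compound 2 therefore holds the only number so far. Compound 3 `O=c1nc2c(ncn2Cc2ccccc2)c(C#CC2CC2)n1Cc1ccccc1` differs from compound 2 by cyclopropyl in place of phenyl on a triple-bonded carbon. Among the measured compounds shown here, the one measured step that bears on this is an at least 14-fold lower number from compound 1 to compound 2 (1.15 log units; beyond the scatter), which introduced the whole 2-phenylethynyl group. Compound 3 keeps the ethynyl link and exchanges only the outer ring, so a smaller shift, toward a higher number, is expected: a 2.9-fold higher number from compound 2 to compound 3 (0.46 log units; beyond the scatter). Compound 3 is estimated at 2 ug/mL, within 0.7 ug/mL to 6 ug/mL.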

Compound 3, half-maximal inhibitory concentration: 0.2 ug/mL
Compound 3: the middle estimate sits 10-fold (1.00 log units) above what was measured; measured number below the stated range.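

In this assay, an aromatic outer ring on the triple-bonded carbon is not required, since cyclopropyl in place of phenyl gives a 3.5-fold lower number from compound 2 to compound 3 (0.54 log units; beyond the scatter). Against the unsubstituted core, 2-cyclopropylethynyl gives an at least 50-fold lower number from compound 1 to compound 3 (1.69 log units; beyond the scatter), so the larger gain also holds with the smaller ring. Compound 1 stands at a limit of the assay: the limit of > 10 ug/mL in this assay, at which 1 of the 3 values shown sits.

Still open, going by these compounds, is how a longer alkyl chain or an amine on the triple-bonded carbon would read. Also open, on these data alone, is whether any group beyond the triple bond is needed, as a plain ethynyl would show.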